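This account rests on a few compounds, and the source may have more. Where it says the series, first, only, none or still open, it means among the compounds named here.

Measured so far in a functional assay on RXF 393 cells (Homo sapiens) for inhibition, read by sulforhodamine B assay, with a stated time of 48 h; a higher number here means that more compound is tolerated, a lower number that less compound is tolerated:

- compound 1 `Nc1cc(N)c2nc(-c3ccccc3)c(Oc3ccc(Cl)c(Cl)c3)nc2c1`: < 100000 nM, a limit of the assay rather than a number.
- compound 2 `CCOC(=O)[C@H](CCC(=O)O)NC(=O)c1ccc(CNc2nc3cc(N)cc(N)c3nc2-c2ccccc2)cc1`: < 100000 nM, also a limit.
- compound 3 `CCOC(=O)[C@H](CCC(=O)O)NC(=O)c1ccc(Sc2nc3cc(N)cc(N)c3nc2-c2ccccc2)cc1`: < 100000 nM, also a limit.

Compound 1 therefore stands nowhere definite on the scale of this assay: only a limit is known for it, and the two further values shown for compounds 2 and 3 are limits as well, so no ordering among the three can be read from these values. The one thing the data state is the limit of < 100000 nM in this assay, at which 3 of the 3 values shown sit, which says only that none of the three exceeded the limit and nothing about how far beneath it any of them lies.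

Compound 4 `Nc1cc(N)c2nc(-c3ccccc3)c(Oc3ccc(F)cc3)nc2c1` is the next member to be measured. It differs from compound 1 in one place: 4-fluorophenyl in place of 3,4-dichlorophenyl on an oxygen on an aromatic ring. Going by the values given here, no step between measured compounds exists, so the size of this change cannot be anchored to a measured shift; with compound 1 itself known only as a limit, the working expectation is no step beyond the scatter.

Compound 4 is expected at 50000 nM, with a range from 10000 nM to 100000 nM. The expected step that the limit leaves unreadable from compound 1 to compound 4 is small, and the result is most likely to be reported again as a limit rather than a number.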

Compound 4, concentration lethal to 50% of the cells: < 100000 nM
Compound 4: a limit, no number; the forecaster's own chance of this, stated with the estimate: 70%; the middle value is on the limit's open side.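

In this assay compound 4 gives < 100000 nM, a limit and not a number. Compound 1 is likewise known only as a limit, so no step can be read between compound 1 and compound 4. The compounds shown leave open how far beneath the limit each one lies, and so any ordering among them: the limit of < 100000 nM in this assay, at which 4 of the 4 values shown sit.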